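Purine benzamides: arylamine versus benzylamine at the ring nitrogen

The compounds below may be only part of what the source reports. "The series", "measured", "known", "first", "only" and "open" are said of these compounds alone.

Measured in a functional assay on HepG2 cells (Homo sapiens) for antiproliferative activity, read by CCK-8 assay, with a stated time of 72 h, tested at 2 uM; a higher number here means a stronger effect of the compound at the concentration tested, a lower number a weaker effect:
compound 1 `Cc1ccc(Nc2nc(Cl)nc3c2ncn3Cc2ccc(C(=O)Nc3ccccc3N)cc2)cc1`: 76.2%
compound 2 `Nc1ccccc1NC(=O)c1ccc(Cn2cnc3c(NCc4ccccc4)nc(Cl)nc32)cc1`: 7.55%
compound 3 `Nc1ccccc1NC(=O)c1ccc(CNc2nc(Cl)nc3c2ncn3C2CCCC2)cc1`: 54.7%

Compound 2 holds the lowest of the three numbers in this assay; compound 3 stands well above it, and compound 1 higher still. Compound 4 `Nc1ccccc1NC(=O)c1ccc(Cn2cnc3c(Nc4cccc(OC(F)(F)F)c4)nc(Cl)nc32)cc1` is not yet measured. It differs from compound 2 by 3-(trifluoromethoxy)phenyl in place of benzyl on a nitrogen on an aromatic ring.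

Among the measured compounds shown here, the one step that bears on this change is a number 68.7 percentage points lower from compound 1 to compound 2 (beyond the scatter), where a benzyl took the place of a phenyl ring bearing a methyl on the same nitrogen on an aromatic ring. For the measured compounds named here, compound 4 goes the other way: a substituted phenyl, not a benzyl, returns to that nitrogen, though the ring now carries a trifluoromethoxy group instead of a methyl, and no measured pair shows what that swap alone does. A large upward step is therefore expected in this assay, roughly the size of the loss seen from compound 1 to compound 2, with some allowance for the different substituent.

For compound 4 the expected value is 62%, within 38% to 82%, which amounts to an estimated step of a number 54.5 percentage points higher from compound 2 to compound 4 (beyond the scatter).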

Compound 4, a percentage reported as inhibition, at one concentration (the size of the read-out at that concentration, not a potency): 1.88%
The estimate for compound 4 lay 60.1 percentage points above the measured number; measured number outside the range, below it.
By their numbers in this assay, from the lowest: compounds 4 and 2 (each within the scatter of the next); then compound 3; then compound 1.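

In this assay, the exchange on the nitrogen on an aromatic ring gives a number 5.7 percentage points lower from compound 2 to compound 4 (within the scatter), so an aromatic ring attached directly to that nitrogen does not by itself restore the number seen for compound 1. Among the compounds shown here, the comparison of the two phenyl groups gives a number 74.3 percentage points lower from compound 1 to compound 4 (beyond the scatter), which shows that the outcome at this position depends strongly on the ring's substituent, and that benzyl is not the only group here tied to a low number. No available evidence accounts for this difference between 4-methylphenyl and 3-(trifluoromethoxy)phenyl.

Still open, on these data alone, is whether the low number follows the trifluoromethoxy group specifically or substitution other than methyl more generally. A plain phenyl, a methoxyphenyl or a chlorophenyl on this nitrogen would help separate these readings.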